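The source may hold more compounds than are shown below. What is called first, only, known or untested is meant among the compounds shown, and "the series" means these compounds.

Two compounds with the shared core have entries in an ADME assay on A549 cells (Homo sapiens) for cytotoxicity, read by LDH release, with a stated time of 15 h (a lower number here means that less compound is tolerated, a higher number that more compound is tolerated), and only one of them has a number. Compound 1 (`O=C(Nc1ccc(NCCCO)cc1Cl)c1cc(Cl)ccc1O`) has the entry "not determined" (no result reported) and so offers no comparison. Compound 2 (`CCCNc1ccc(NC(=O)c2cc(Cl)ccc2O)c(Cl)c1`) reads 69700 nM and is the sole numerical anchor, with no other value to rank it against. Compound 3 (`O=C(Nc1ccc(NCc2ccco2)cc1Cl)c1cc(Cl)ccc1O`) has yet to be measured. Its difference from compound 2 counts out as follows: furan-2-yl in place of ethyl on a saturated chain carbon bound to a nitrogen on an aromatic ring. In words, furan-2-yl stands in place of ethyl on a saturated chain carbon bound to a nitrogen on an aromatic ring, which also reads as propyl to (furan-2-yl)methyl. Going by the values given here, no step between measured compounds is available to size this change, so the expectation rests on compound 2 at 69700 nM alone. A modest fall in this assay is expected, meaning somewhat less compound tolerated, and the estimated move is a 1.7-fold lower number from compound 2 to compound 3 (0.22 log units; within the scatter) with wide uncertainty. Compound 3 is estimated at 42000 nM in this assay, with an expected range from 14000 nM to 100000 nM as the working bounds.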

Compound 3, half-maximal cytotoxic concentration: 76300 nM
The estimate for compound 3 lay 1.8-fold (0.26 log units) below the measured number; the measured number falls inside the stated range.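

Going by these compounds alone, this is the first readable step at this place: in this assay, furan-2-yl in place of ethyl on a saturated chain carbon bound to a nitrogen on an aromatic ring gives a 1.1-fold higher number from compound 2 to compound 3 (0.04 log units; within the scatter). A five-membered aromatic ring with a hydrogen-bond acceptor therefore enters where a ring-free ethyl stood, and the numbers for the two compounds stay within the scatter of each other, so this pair does not separate in this assay. Nothing is available that would account for this result.

As far as these compounds go, compound 1, which carries a hydroxyl on its chain, stands at "not determined" (no result reported) in this assay, so the steps to it cannot be read and the effect of that hydroxyl remains unknown. Also open, from the compounds shown here alone, is how a carboxylic acid, a dimethylamino group or a longer chain such as hexyl would read at this place in this assay, and whether any replacement here moves the number beyond the scatter.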